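Fluoro to nitro on the aryl ring: expecting compound 3

The source may report more compounds than this note shows. Statements on the series, on what has been measured and on what is new or still open speak of the compounds shown alone.

Measured so far in an ADME assay on cells (Macrophage, Homo sapiens) for cytotoxicity, read by MTT assay, with a stated time of 24 h; on this read-out lower numbers stand for higher toxicity in this test and higher numbers for lower toxicity in this test:
Compound 1 `CC(O)Cn1c([N+](=O)[O-])cnc1/C=C/c1ccc(Br)cc1` gives 550 nM.
Compound 2 `CC(O)Cn1c([N+](=O)[O-])cnc1/C=C/c1ccc(F)cc1` gives 420 nM.

Among the measured compounds shown here, compound 2 shows the lowest of the two numbers, but its only neighbour is compound 1, and the step of a 1.3-fold lower number from compound 1 to compound 2 (0.12 log units; within the scatter) lies within the scatter, so on these data the two cannot be told apart. Compound 3 `CC(O)Cn1c([N+](=O)[O-])cnc1/C=C/c1ccc([N+](=O)[O-])cc1` has not yet been measured. It differs from compound 2 in a single place: nitro in place of fluoro on an aromatic carbon. For the measured compounds named here, the one measured step, the exchange of one halogen for another on the same aromatic carbon, is the only comparison available, and it changed nothing beyond the scatter; it says nothing directly about a nitro group, which is a different kind of substituent entirely. Going by the values given here, with no measured step that speaks to this change, the expectation in this assay is for no shift beyond the scatter, held with a wide range. Compound 3 is therefore estimated at 450 nM, between 180 nM and 1100 nM. This corresponds to an expected step of a 1.1-fold higher number from compound 2 to compound 3 (0.03 log units; within the scatter).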

Compound 3, half-maximal cytotoxic concentration: 410 nM
Compound 3: middle estimate off by 1.1-fold (0.04 log units), on the high side, within the range that was stated.
By their numbers in this assay, from the lowest: compounds 3, 2 and 1 (each within the scatter of the next).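

Nitro is a different kind of group from the halogens, with more heavy atoms and with hydrogen-bond acceptors that fluoro lacks, yet in this assay this exchange gives a 1.0-fold lower number from compound 2 to compound 3 (0.01 log units; within the scatter), and the exchange against bromo gives a 1.3-fold lower number from compound 1 to compound 3 (0.13 log units; within the scatter). Until now, this aromatic carbon had only been tested with one halogen in place of another; across these three compounds, the number stays within the scatter even with a non-halogen group there, and none of the three goes against this. No measurement shown here offers an explanation for this insensitivity of the toxicity read-out to the group at this position.

Still open, from the compounds shown here alone, is whether an amine, a carboxylic acid or a longer chain on this same aromatic carbon, or simply hydrogen in place of the group, would move the number beyond the scatter. Also open, going by these compounds, is whether changes elsewhere on the shared core, such as replacing its hydroxyl group with an amine, would matter more than the three groups compared here.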